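A few compounds are considered here, and "the series" means these few. Any claim that something is new, unique, unknown or untested is made for them only; others in the source may bear on it.

Measured so far in a functional assay on NCI-H460 cells (Homo sapiens) for inhibition, read by MTT assay, with a stated time of 24 h, tested at 10 ug/mL; on this read-out higher numbers stand for more inhibition of growth at the one concentration tested and lower numbers for less inhibition of growth:

- compound 1 `O=C(O)CCCCC(CCSC(=O)c1ccccc1)SC(=O)c1ccccc1`: "not active" (no number reported)
- compound 2 `O=C(CCCCC(S)CCS)NO`: 17.7%

Compound 1 has no single number to serve as a starting point, since the result for compound 1 is simply "not active" (no number reported). The only numerical result is for compound 2, at 17.7%. Among the measured compounds shown here, no two measured compounds here differ in just one place, so the data offer no step size to borrow.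

The next compound to test is compound 3 `O=C(CCCCC(CCSC(=O)c1ccccc1)SC(=O)c1ccccc1)Nc1cccc(Cl)c1`, which keeps the core of compound 1. The structural change is (3-chlorophenyl)amino in place of hydroxy on a carbonyl carbon, with (3-chlorophenyl)amino in place of hydroxy on a carbonyl carbon. In this assay, a modest upward step is expected from the starting point of compound 1 at "not active" (no number reported), though a step no larger than the scatter remains possible. The estimated growth inhibition for compound 3 is 20%, with an expected range of 0% to 50%.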

Compound 3, percent growth inhibition at one concentration: 9.12%
Compound 3: the middle estimate sits 10.9 percentage points above what was measured, within the range that was stated.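

No step can be read from compound 1 to compound 3: the result for compound 1 is "not active" (no number reported) and offers no number to compare with. Whether (3-chlorophenyl)amino in place of hydroxy changes growth inhibition stays open, and nothing measured here offers an explanation for either result.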